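Cyclopentenone series: cytotoxicity limits and a phenyl analogue

The source may report more compounds than this note shows. Statements on the series, on what has been measured and on what is new or still open speak of the compounds shown alone.

compound 1 `COc1ccc(C2=C(c3cc(OC)c(OC)c(OC)c3)C(=O)CC2O[SiH2]C(C)(C)C)cc1OC` — > 100 ug/mL
compound 2 `C=CCOc1cc(C2=C(c3cc(OC)c(OC)c(OC)c3)C(=O)C(O)C2)ccc1OC` — > 100 ug/mL
compound 3 `COc1ccc(OC)c(C2=C(c3cc(OC)c(OC)c(OC)c3)C(=O)CC2O)c1` — > 100 ug/mL

In an ADME assay on ECV-304 cells (Homo sapiens) for cytotoxicity, read by MTT assay, with a stated time of 72 h (on this read-out higher numbers stand for weaker inhibition and lower numbers for stronger inhibition), compound 1 gives > 100 ug/mL, which is a limit of the assay rather than a number. Compound 2 gives > 100 ug/mL in this assay, again a limit. Compound 3 gives > 100 ug/mL in this assay, also a limit. Compound 1 therefore stands where every value shown stands, at the limit of > 100 ug/mL in this assay, at which 3 of the 3 values shown sit. Going by the values given here, no two measured compounds differ in a single place, so no measured step is available to set a scale.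

Compound 4 `COc1cc(C2=C(c3ccccc3)C(O[SiH2]C(C)(C)C)CC2=O)cc(OC)c1OC` is the compound still to be measured. Compared with compound 1 it carries phenyl in place of 3,4-dimethoxyphenyl on a double-bonded ring carbon. With all three values shown sitting at the same limit, the step in this assay is expected to be none beyond the scatter, in no particular direction. For compound 4 the value in this assay is estimated at 100 ug/mL, with a range of 50 ug/mL to 200 ug/mL. The step of a number no higher from compound 1 to compound 4 (the limit leaves the size open) is expected to be small, most likely ending at the same limit.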

Compound 4, half-maximal inhibitory concentration: > 100 ug/mL
Compound 4 ended at the assay's limit; the forecaster's own chance of this, stated with the estimate: 75%; the middle value lies on the limit itself.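

In this assay compound 4 gives > 100 ug/mL, a limit of the assay. No step from compound 1 to compound 4 can be read, because both sit at one limit: the limit of > 100 ug/mL in this assay, at which 4 of the 4 values shown sit.

The compounds shown leave open what change to the shared core would yield a measurable value in this assay.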